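Iodo in Place of Cyano: What Happens to Half-Life

This account rests on a few compounds, and the source may have more. Where it says the series, first, only, none or still open, it means among the compounds named here.

Measured so far:
Compound 1, `CC#C[C@@H](Cc1nnn[nH]1)c1ccc(OCc2ccc3sc(C#N)c(-c4ccccc4C)c3c2)cc1`, gives 0.0333 h.
Compound 2, `CC#C[C@@H](Cc1nnn[nH]1)c1ccc(OCc2ccc3scc(-c4ccc(OCCCS(C)(=O)=O)cc4C)c3c2)cc1`, gives 1.28 h.

In an ADME assay on microsomes from liver (Homo sapiens) for metabolic stability (a lower number here means that the compound disappears faster, a higher number that the compound lasts longer), compound 1 stands at the lowest of the two numbers; compound 2 sits far above it, a gap beyond the usual scatter. Compound 3, `CC#C[C@@H](Cc1nnn[nH]1)c1ccc(OCc2ccc3sc(I)c(-c4ccccc4C)c3c2)cc1`, has not been measured. It differs from compound 1 by iodo in place of cyano on an aromatic carbon. Among the measured compounds shown here, no measured pair shows this single change, so no step can be taken from the data. The step of a 1.4-fold higher number from compound 1 to compound 3 (0.13 log units; within the scatter) is expected to be small, within the scatter, with no clear direction. Compound 3 is estimated at 0.045 h, in a range from 0.015 h to 0.14 h.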

Compound 3, half-life: 0.167 h
The estimate for compound 3 lay 3.7-fold (0.57 log units) below the measured number; the whole stated range lies below it.
By their numbers in this assay, from the lowest: compound 1; then compound 3; then compound 2.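

In this assay, putting iodo in place of cyano on the aromatic carbon next to the ring sulfur gives a 5.0-fold higher number from compound 1 to compound 3 (0.70 log units; beyond the scatter), so this position does influence how long the compound lasts. The earlier compounds shown here could not show this, since they differ in more than one place. No measurement shown explains why the number moves.

Going by these compounds, whether a different group here, such as an amine or a carboxylic acid, would give a longer half-life stays open. So does whether this same change would have a similar effect on another core.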